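Methyl removal on two cores: expected to stay inactive

This account rests on a few compounds, and the source may have more. Where it says the series, first, only, none or still open, it means among the compounds named here.

The series holds two small cores. Compound 1 `CSc1nncc2c(C)nc(C(C)C)n12` and compound 2 `CCc1nc(C)c2cnnc(SC)n12` share one core; compound 3 `CCc1ncn2c(S)nncc12` and compound 4 `Cc1ncn2c(S)nncc12` share another, and the difference between the two cores is not broken down here. In a functional assay for inhibition, with Homo sapiens as the target (a lower number here means a stronger inhibitor, a higher number a weaker inhibitor), compound 1 gives only a limit, > 48000 nM. In this assay compound 2 likewise gives only a limit, > 48000 nM. In this assay compound 3 also gives only a limit, > 48000 nM. All three values sit at the limit of > 48000 nM in this assay, at which 3 of the 3 values shown sit. The change hydrogen in place of methyl on a saturated chain carbon bound to an aromatic carbon and a saturated chain carbon gave a step that the two limits leave unreadable from compound 1 to compound 2. From compound 3 to compound 4 the change is hydrogen in place of methyl on a saturated chain carbon bound to an aromatic carbon; it is the same kind of change, the place differing in that here the saturated chain carbon is bound to an aromatic carbon only and not also to a saturated chain carbon. Compound 4 has not been measured in this assay. Because the earlier step reads a step that the two limits leave unreadable from compound 1 to compound 2, the expected step is a step that the limit leaves unreadable from compound 3 to compound 4, with no reason in the measured compounds to expect a readable number. Compound 4 is estimated at 60000 nM, between 25000 nM and 150000 nM, and most likely again only a limit.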

Compound 4, half-maximal inhibitory concentration: > 48000 nM
Compound 4: a limit, no number (the forecaster's own chance of this, stated with the estimate: 90%); the middle value does not contradict the limit.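

Compound 3 and compound 4 both give only a limit, so no new step can be read between them, and the series stays where it stood: the limit of > 48000 nM in this assay, at which 4 of the 4 values shown sit.
Left open is whether in this assay either core can give a readable value at all, and so what the change from methyl to hydrogen does on these cores.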